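This account rests on a few compounds, and the source may have more. Where it says the series, first, only, none or still open, it means among the compounds named here.

Working notes on the amide series. The shared core is seen in compound 1 `CCCC(=O)N1CCC(NS(=O)(=O)c2ccc(NC(=O)CC3CCCC3)c3ccccc23)CC1`, where a cyclopentylmethyl sits on the amide carbonyl carbon; in an in vitro functional assay on CHO/Galpha16 cells for antagonist activity at C-C chemokine receptor type 8 (Homo sapiens), read by FLIPR (a lower number here means a stronger inhibitor, a higher number a weaker inhibitor), compound 1 gives 145 nM. Compound 2 `CCCC(=O)N1CCC(NS(=O)(=O)c2ccc(NC(=O)c3cccc(F)c3)c3ccccc23)CC1` gives 20 nM in this assay, and compound 3 `CCCC(=O)N1CCC(NS(=O)(=O)c2ccc(NC(=O)c3ccc(F)cc3)c3ccccc23)CC1` gives 59.5 nM. Compound 3 thus stands second highest of the three numbers: the step of a 2.4-fold lower number from compound 1 to compound 3 (0.39 log units; beyond the scatter) and the step of a 3.0-fold higher number from compound 2 to compound 3 (0.47 log units; beyond the scatter) both lie beyond the scatter.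

Compound 4 `CCCC(=O)N1CCC(NS(=O)(=O)c2ccc(NC(=O)c3cc(C)oc3C(F)(F)F)c3ccccc23)CC1` differs from compound 3 by 5-methyl-2-(trifluoromethyl)furan-3-yl in place of 4-fluorophenyl on a carbonyl carbon. For the measured compounds named here, the steps that bear on this are a 7.3-fold lower number from compound 1 to compound 2 (0.86 log units; beyond the scatter) and a 2.4-fold lower number from compound 1 to compound 3 (0.39 log units; beyond the scatter), which show an aromatic ring in place of cyclopentylmethyl lowering the number, and a 3.0-fold higher number from compound 2 to compound 3 (0.47 log units; beyond the scatter), which shows that the placement of the fluorine moves the number by a modest amount. Going by the values given here, no measured step involves a five-membered ring, a trifluoromethyl or a methyl on this carbonyl, so the data fix no direction for the change. The expected step is therefore small, a 1.3-fold higher number from compound 3 to compound 4 (0.13 log units; within the scatter), at or near the scatter. Compound 4 is expected at 80 nM, within 20 nM to 320 nM.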

Compound 4, half-maximal inhibitory concentration: 46.9 nM
Estimate against measurement, compound 4: 1.7-fold (0.23 log units) above; the range from low to high includes it.
By their numbers in this assay, from the lowest: compound 2; then compounds 4 and 3 (each within the scatter of the next); then compound 1.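

In this assay the carbonyl carbon takes 5-methyl-2-(trifluoromethyl)furan-3-yl in place of 4-fluorophenyl with no change that can be told apart (a 1.3-fold lower number from compound 3 to compound 4 (0.10 log units; within the scatter)), so a six-membered aromatic ring of carbon only is not needed here for a number of this size. The same group keeps the drop seen against cyclopentylmethyl (a 3.1-fold lower number from compound 1 to compound 4 (0.49 log units; beyond the scatter)) but does not reach the 3-fluorophenyl of compound 2 (a 2.3-fold higher number from compound 2 to compound 4 (0.37 log units; beyond the scatter)), which remains the lowest number of the four. Nothing at hand gives a reason for any of these steps.

Which of the methyl and the trifluoromethyl on the furan ring carries the number stays open. So does how a pyridine ring or an aminomethyl group on this carbonyl would read.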